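The compounds below may be only part of what the source reports. "The series", "measured", "known", "first", "only" and "open" are said of these compounds alone.

Measured compounds:
Compound 1: `COc1ccc(-c2cnc(C(=O)CCCCCCc3ccccc3)o2)cc1` — 100 nM
Compound 2: `NC(=O)c1ccc(-c2cnc(C(=O)CCCCCCc3ccccc3)o2)cc1` — 10 nM

Going by the values given here, in an assay (Rattus norvegicus) for inhibition of Fatty-acid amide hydrolase 1 (Homo sapiens) (a higher number here means a weaker inhibitor, a lower number a stronger inhibitor), compound 2 gives 10 nM, the lowest of the two numbers measured so far. The nearest measured compound is compound 1, which in this assay gives 100 nM. Among the compounds with values here, the single measured step, a 10-fold lower number from compound 1 to compound 2 (1.00 log units; beyond the scatter), is the only one and the only one that bears on the next change.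

Compound 3 is `N#Cc1ccc(-c2cnc(C(=O)CCCCCCc3ccccc3)o2)cc1`. The change from compound 2 is cyano in place of carbamoyl on an aromatic carbon. Within the data shown here, no measured step covers a cyano group at this place; the one that exists exchanged methoxy for carbamoyl and moved the number down by a modest amount. The cyano group keeps one hydrogen-bond acceptor but, as counted, carries no hydrogen-bond donor, which the carbamoyl group had. The expectation is therefore a small rise in the number, a 3.0-fold higher number from compound 2 to compound 3 (0.48 log units; beyond the scatter), staying nearer to compound 2 than to compound 1. Compound 3 is estimated at 30 nM in this assay, with a range from 10 nM to 100 nM.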

Compound 3, inhibition constant: 40 nM
Compound 3: middle estimate off by 1.3-fold (0.12 log units), on the low side; low and high end bracket the measured number.
By their numbers in this assay, from the lowest: compound 2; then compound 3; then compound 1.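

Working notes on the carbon para to a large group: in this assay, going from 4-carbamoylphenyl to 4-cyanophenyl gives a 4.0-fold higher number from compound 2 to compound 3 (0.60 log units; beyond the scatter), so at this position cyano does not match carbamoyl. Cyano still keeps part of the gain over methoxy, with a 2.5-fold lower number from compound 1 to compound 3 (0.40 log units; beyond the scatter), which places the three groups in a clear order at this one carbon: carbamoyl gives the lowest number, cyano the middle one and methoxy the highest. The change removes the hydrogen-bond donor and also one heavy atom, so this single step cannot separate those two differences, and no available data bear on why the numbers fall in this order.

An N-methyl amide or a sulfonamide at the same carbon could help show whether the amide hydrogen matters, while a carboxylic acid or an amine would extend the range of groups compared there. Going by these compounds, it also remains open whether this order holds with a shorter or longer chain on the carbonyl, since all three compounds share the same chain.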